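Chain extension at the amino substituent: compound 3 to compound 4

A few compounds are considered here, and "the series" means these few. Any claim that something is new, unique, unknown or untested is made for them only; others in the source may bear on it.

Measured so far in an assay on isolated protein for binding affinity to corticotropin-releasing factor receptor 1 (Homo sapiens); a higher number here means a weaker inhibitor, a lower number a stronger inhibitor:
compound 1 `CCCN(CCC#N)c1nc(C)nc(N(CC)c2ccc(N(C)C)cc2C)n1`: 7 nM
compound 2 `CCCN(CCC)c1nc(C)nc(N(CC)c2ccc(N(C)C)cc2C)n1`: 7 nM
compound 3 `CCCCN(CC#N)c1nc(C)nc(N(CC)c2ccc(N(C)C)cc2C)n1`: 8 nM

Compound 3 holds the highest of the three numbers, but the gaps to the others are within the scatter: a 1.1-fold higher number from compound 1 to compound 3 (0.06 log units; within the scatter) and a 1.1-fold higher number from compound 2 to compound 3 (0.06 log units; within the scatter). The three compounds share the whole core and differ only in the two chains on the amino group attached to it.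

Compound 4 `CCCCN(CCC#N)c1nc(C)nc(N(CC)c2ccc(N(C)C)cc2C)n1` is the next member. It differs from compound 3 by cyanomethyl in place of cyano on a saturated chain carbon bound to a nitrogen on an aromatic ring. Two of the measured steps bear on this. The step of no change at the digits printed from compound 1 to compound 2 (within the scatter) shows that exchanging cyano for methyl at the chain end leaves the number as it is. The step of a 1.1-fold higher number from compound 2 to compound 3 (0.06 log units; within the scatter), which moves between dipropylamino and butyl(cyanomethyl)amino, also stays within the scatter. Among the compounds with values here, nothing among the measured compounds suggests that the length of the cyano-bearing chain shifts the readout, so no step beyond the scatter is expected: no change at the digits printed from compound 3 to compound 4 (within the scatter).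

For compound 4 the estimate in this assay is 8 nM, expected to fall between 4 nM and 16 nM.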

Compound 4, inhibition constant: 8 nM
Beside the measured number, compound 4's estimate shows no gap at the digits printed; the range from low to high includes it.
By their numbers in this assay, from the lowest: compounds 1, 2, 3 and 4 (each within the scatter of the next).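

In this assay, within the data shown here, cyanomethyl in place of cyano on a saturated chain carbon bound to a nitrogen on an aromatic ring gives no change at the digits printed from compound 3 to compound 4 (within the scatter) and is the first direct read on the length of the nitrile-bearing chain with butyl held as the other chain. Butyl(2-cyanoethyl)amino in place of dipropylamino gives a 1.1-fold higher number from compound 2 to compound 4 (0.06 log units; within the scatter) and methyl in place of hydrogen on a saturated chain carbon, three bonds along the chain from a nitrogen on an aromatic ring, gives a 1.1-fold higher number from compound 1 to compound 4 (0.06 log units; within the scatter) so that every pair among these four amino substituents now lies within the scatter. Nothing available explains this result.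

The compounds shown leave open whether a longer chain ending in nitrile would also stay within the scatter. On these data alone, a chain ending in an amine or a carboxylic acid also remains open.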